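This account rests on a few compounds, and the source may have more. Where it says the series, first, only, none or still open, it means among the compounds named here.

Compound 1 `CC(C)(C)c1ccc(OC(Cc2ccc(Cl)cc2)C(=O)O)cc1`: 25 mg/kg
Compound 2 `CC(C)c1ccc(OC(C)(Cc2ccc3c(c2)CCC3)C(=O)O)cc1`: 0.5 mg/kg
Compound 3 `CC(Cc1ccc(Cl)cc1)(Oc1ccc(Cc2ccc(Cl)cc2)cc1)C(=O)O`: > 10 mg/kg (a limit)

All three were tested in a functional assay on the whole organism for inhibition, with Rattus norvegicus as the target; a higher number here means that more compound is needed for the effect, a lower number that less compound is needed. Compound 2 has the lower of the two exact numbers, and compound 1 lies above it by more than the scatter. For compound 3, the result > 10 mg/kg is a limit only, and this compound also differs from compound 2 elsewhere in its structure.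

Compound 4 `CC(Cc1ccc2c(c1)CCC2)(Oc1ccc(Cc2ccccc2)cc1)C(=O)O` has yet to be measured. It differs from compound 2 by benzyl in place of isopropyl on an aromatic carbon, para to a large group. For the measured compounds named here, no measured pair isolates this change. Compound 3, with a chlorinated benzyl there, gave the limit > 10 mg/kg, so a higher number is expected. The expected change is a 6.0-fold higher number from compound 2 to compound 4 (0.78 log units; beyond the scatter), beyond the scatter. For compound 4 the estimated value is 3 mg/kg, with an expected range of 0.6 mg/kg to 15 mg/kg.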

Compound 4, dose for half-maximal effect: 0.5 mg/kg
For compound 4 the middle estimate is 6.0-fold (0.78 log units) above the measured one; measured number below the stated range.
By their numbers in this assay, from the lowest: compounds 2 and 4 (each within the scatter of the next); then compound 1.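

Replacing isopropyl with benzyl on an aromatic carbon, para to a large group, gives no change at the digits printed from compound 2 to compound 4 (within the scatter) in this assay. This place therefore accepts 7 heavy atoms and a six-membered aromatic ring in place of 3 heavy atoms with no ring, with no change beyond the scatter. Compound 3 provides only a limit, not a number to set beside this step: the limit of > 10 mg/kg in this assay, at which 1 of the 4 values shown sits.

Going by these compounds, whether a cyclohexyl group, a longer chain or an amine at this place would fit as well remains open. So does whether a methoxy group on the benzyl ring would alter the value.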